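Cyano for nitro on the aryl ring of compound 2

A few compounds are considered here, and "the series" means these few. Any claim that something is new, unique, unknown or untested is made for them only; others in the source may bear on it.

The series shares one core, shown in compound 1 `Cc1cc(-c2ccsc2)cn2c(CSCCc3ccccc3)cnc12` and compound 2 `Cc1cc(-c2cccc([N+](=O)[O-])c2)cn2c(CSCCc3ccccc3)cnc12`, which differ only in the aryl group on the bicyclic ring. In an ADME assay on HEL cells (Homo sapiens) for cytotoxicity, with a stated time of 3 days (on this read-out higher numbers stand for lower toxicity in this test and lower numbers for higher toxicity in this test), compound 1 gives >= 4 ug/mL, a limit of the assay and not a number. In this assay compound 2 gives >= 100 ug/mL, again a limit of the assay. The step that the two limits leave unreadable from compound 1 to compound 2 therefore cannot be read, since it runs from the limit of >= 4 ug/mL in this assay, at which 1 of the 2 values shown sits, to the limit of >= 100 ug/mL in this assay, at which 1 of the 2 values shown sits. Compound 2 thus stands at the upper limit of the values shown, with no number of its own. Compound 3 `Cc1cc(-c2cccc(C#N)c2)cn2c(CSCCc3ccccc3)cnc12` carries cyano in place of nitro on an aromatic carbon. Among the measured compounds shown here, no measured step covers this change, and the one measured step gives no size. With compound 2 at the limit of >= 100 ug/mL in this assay, at which 1 of the 2 values shown sits, compound 3 is expected to stay near that limit, a step of a number no higher from compound 2 to compound 3 (the limit leaves the size open), and its value is estimated at 100 ug/mL, between 35 ug/mL and 100 ug/mL.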

Compound 3, minimum cytotoxic concentration: > 100 ug/mL
Compound 3: only a limit was reported (the forecaster's own chance of this, stated with the estimate: 70%); the middle value lies on the limit itself.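

In this assay compound 3 gives > 100 ug/mL, a limit of the assay and not a number. Neither new step, from compound 2 to compound 3 or from compound 1 to compound 3, can be read. The compounds shown leave open where the actual minimum cytotoxic concentrations of compound 1, compound 2 and compound 3 lie.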